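Swapping the acetyl methyl for a cyclohexyl ester

This account rests on a few compounds, and the source may have more. Where it says the series, first, only, none or still open, it means among the compounds named here.

Of the compounds shown here, two sharing one core have been tested in an assay on membranes from CHO cells for displacement of a labelled ligand from adenosine receptor A1 (Homo sapiens), read by scintillation counting, with a stated time of 60 min, tested at 1 uM; a lower number here means less inhibition, a higher number more inhibition at the concentration tested (going by the name of the read-out). Compound 1 `CC(=O)C1=C(C)NC(=O)NC1c1ccoc1` gives 6%, the lower of the two numbers, and compound 2 `CC1=C(c2ncc(C)o2)C(c2ccoc2)NC(=O)N1` gives 21%, with the step of a number 15 percentage points higher from compound 1 to compound 2 (beyond the scatter). Compound 3 `CC1=C(C(=O)OC2CCCCC2)C(c2ccoc2)NC(=O)N1` differs from compound 1 by cyclohexyloxy in place of methyl on a carbonyl carbon. For the measured compounds named here, no measured step touches that carbonyl carbon directly; the step from compound 1 to compound 2 alters a different group. Compound 3 is therefore expected to move little, with a step of a number 6 percentage points higher from compound 1 to compound 3 (within the scatter) estimated, and an estimated value of 12% within 0% to 30%.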

Compound 3, a percentage reported as inhibition, at one concentration (the size of the read-out at that concentration, not a potency): 15%
For compound 3 the middle estimate is 3 percentage points below the measured one; the measured number falls inside the stated range.
By their numbers in this assay, from the lowest: compounds 1, 3 and 2 (each within the scatter of the next, the first and the last beyond it).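

The carbonyl carbon now has a measured change of its own: in this assay, cyclohexyloxy in place of methyl gives a number 9 percentage points higher from compound 1 to compound 3 (within the scatter). A much larger group carrying a six-membered non-aromatic ring therefore leaves the number within the scatter of that of compound 1, at this single concentration. Nothing available bears on the reason for this result. Still open, on these data alone, is whether a smaller ethoxy group, or an amine, on the same carbonyl carbon would give a number beyond the scatter of that of compound 1.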